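The source may report more compounds than this note shows. Statements on the series, on what has been measured and on what is new or still open speak of the compounds shown alone.

Compound 1 `CCC(=O)Oc1c(OC)c(OC)c(OC(=O)CC)c2ccccc12` and compound 2 `CCC(=O)Oc1c(OC)c(OC)c(OC(=O)CC)c2cc(OC)ccc12` share one core and have both been measured in a physicochemical assay for lipophilicity; on this read-out higher numbers stand for higher lipophilicity and lower numbers for lower lipophilicity. There, compound 1 gives 3.44 and compound 2 gives 3.28, so the two stand within the usual scatter of each other. Compound 3 `CCC(=O)Oc1c(OC)c(OC)c(OC(=O)CC)c2c(C)cccc12` has not yet been measured in this assay. It differs from compound 1 by one substitution, methyl in place of hydrogen on an aromatic carbon.

For the measured compounds named here, only one measured step bears on this change: a number 0.16 log units lower from compound 1 to compound 2 (within the scatter), for methoxy in place of hydrogen on an aromatic carbon. Going by the values given here, that step is a guide only in part, since it brings in a different group at a different place on the core, and no measured compound carries the methyl group. It shows that one substitution on this ring system need not move the number far, yet it does not settle the direction for methyl. A modest move towards a higher number is nevertheless expected, and the step expected is a number 0.31 log units higher from compound 1 to compound 3 (beyond the scatter). For compound 3 the estimated value in this assay is 3.75, with an expected range from 3.4 to 4.1.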

Compound 3, partition coefficient: 3.9
Compound 3: the middle estimate sits 0.15 log units below what was measured; measured number inside the range.
By their numbers in this assay, from the lowest: compounds 2 and 1 (each within the scatter of the next); then compound 3.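

In this assay, for the compounds shown here, methyl in place of hydrogen on this aromatic carbon, ortho to a fused ring and meta to a fused ring, gives the first step on the shared core that lies beyond the scatter (a number 0.46 log units higher from compound 1 to compound 3 (beyond the scatter)). Going by these compounds alone, the only earlier step (a number 0.16 log units lower from compound 1 to compound 2 (within the scatter)) stayed within the scatter, and it brought in methoxy at a different place, so it could not show what this carbon tolerates or which way methyl would go; the new step gives that direction for this one group at this one place. No measurement at hand accounts for the size or direction of this step.

With a single methyl compound to go on, the compounds shown leave open whether a longer chain such as ethyl, or a halogen such as chlorine, on this same carbon would follow the same direction, and by how much. They also leave open whether methyl at the carbon carrying methoxy in compound 2 would give a step like the one seen here, or whether this step belongs to this place alone.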